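The compounds below may be only part of what the source reports. "The series", "measured", "known", "first", "only" and "open" are said of these compounds alone.

Measured so far:
compound 1 `Nc1cc(N)c2nc(-c3ccccc3)c(NCc3ccc(Cl)c(Cl)c3)nc2c1` — in a functional assay on UACC-257 cells (Homo sapiens) for inhibition, read by sulforhodamine B assay, with a stated time of 48 h (on this read-out lower numbers stand for higher toxicity in this test and higher numbers for lower toxicity in this test), compound 1 gives 43700 nM
compound 2 `Nc1cc(N)c2nc(-c3ccccc3)c(NCc3ccc(F)cc3)nc2c1` — in this assay compound 2 gives 8910 nM

Among the measured compounds shown here, compound 2 holds the lower of the two numbers; the only measured step is a 4.9-fold lower number from compound 1 to compound 2 (0.69 log units; beyond the scatter), which exchanges 4-fluorophenyl for 3,4-dichlorophenyl on a saturated chain carbon bound to a nitrogen on an aromatic ring.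

Compound 3 `COc1ccc(CNc2nc3cc(N)cc(N)c3nc2-c2ccccc2)cc1` differs from compound 2 by methoxy in place of fluoro on an aromatic carbon. For the measured compounds named here, no measured step touches a fluoro-to-methoxy exchange: the single known step alters the halogen pattern of that ring and gives no guide to this substitution. With no bearing evidence, the expected step of a 1.0-fold higher number from compound 2 to compound 3 (0.00 log units; within the scatter) is none beyond the scatter, and the range is kept wide. For compound 3 in this assay the estimate is 9000 nM, expected to fall between 3000 nM and 27000 nM.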

Compound 3, concentration lethal to 50% of the cells: 56200 nM
The estimate for compound 3 lay 6.2-fold (0.80 log units) below the measured number; the measured number lies above the stated range.
By their numbers in this assay, from the lowest: compound 2; then compounds 1 and 3 (each within the scatter of the next).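

In this assay the para position of the benzyl ring proves sensitive to a single exchange: fluoro to methoxy gives a 6.3-fold higher number from compound 2 to compound 3 (0.80 log units; beyond the scatter), a change in one group that the earlier step, with its altered halogen pattern, could not isolate. 4-Methoxyphenyl and 3,4-dichlorophenyl cannot be told apart, with a 1.3-fold higher number from compound 1 to compound 3 (0.11 log units; within the scatter), so among the three compounds only compound 2 stands apart from the others, its higher toxicity in this test resting on a single group. Nothing available accounts for this step.

Still open, on these data alone, is whether the low number belongs to fluoro alone or would also appear with an unsubstituted phenyl, 4-chlorophenyl or 4-hydroxyphenyl in that place. Also open, as far as these compounds go, is how a longer chain carrying the same 4-fluorophenyl would read.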